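A few compounds are considered here, and "the series" means these few. Any claim that something is new, unique, unknown or untested is made for them only; others in the source may bear on it.

Of the compounds shown here, three have been measured in an ADME assay on Raji cells (Homo sapiens) for cytotoxicity, read by CellTiter-Glo and resazurin assay, with a stated time of 72 h; a lower number here means that less compound is needed, a higher number that more compound is needed for the effect.

Compound 1, `CC(=O)Nc1cccc(-c2ccc(C(=O)N(Cc3cccc(OCCCCCC(=O)O)c3)C(C)C)cc2)c1`: in this assay compound 1 gives > 26000 nM, which is a limit of the assay and not a number.
Compound 2, `CC(C)N(Cc1cccc(OCCCCCC(=O)O)c1)C(=O)c1ccc(-c2ccco2)cc1`: in this assay compound 2 gives > 26000 nM, again a limit.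
Compound 3, `CC(C)N(Cc1cccc(OCCCCCC(=O)O)c1)C(=O)c1ccc(-c2ccc3[nH]ccc3c2)cc1`: in this assay compound 3 gives > 26000 nM, also a limit.

Compound 3 thus stands where every measured compound stands, namely at the limit of > 26000 nM in this assay, at which 3 of the 3 values shown sit. None of the three is separated from another by a readable step: a step that the two limits leave unreadable from compound 1 to compound 2, a step that the two limits leave unreadable from compound 1 to compound 3 and a step that the two limits leave unreadable from compound 2 to compound 3 are all hidden by the limits.

Compound 4 is `CC(C)N(Cc1cccc(OCCCCCC(=O)O)c1)C(=O)c1ccc(-c2c[nH]c3ccccc23)cc1`. It differs from compound 3 in one place: 1H-indol-3-yl in place of 1H-indol-5-yl on an aromatic carbon. Within the data shown here, the steps that bear on this change are the two that lead into compound 3, and both were unreadable, so the only thing they show is that exchanging the group on this aromatic carbon has not yet brought any compound under the limit. Compound 4 is therefore expected to remain at the limit too, with a step that the limit leaves unreadable from compound 3 to compound 4 expected to be no step beyond the scatter. The estimate for compound 4 in this assay is 40000 nM, expected to lie between 15000 nM and 120000 nM, and most likely to be reported as a limit rather than a number.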

Compound 4, half-maximal effective concentration: > 26000 nM
Compound 4 ended at the assay's limit; the forecaster's own chance of this, stated with the estimate: 85%; the middle value is on the limit's open side.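

In this assay compound 4 gives > 26000 nM, which is a limit of the assay, so its steps from compound 1, compound 2 and compound 3 cannot be read. The compounds shown leave open whether any group on this aromatic carbon gives a value under the limit, for all of them stand at one place: the limit of > 26000 nM in this assay, at which 4 of the 4 values shown sit.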